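Dibromo dimethoxyphenyl hydrazones: aryl change on the thiazole

A few compounds are considered here, and "the series" means these few. Any claim that something is new, unique, unknown or untested is made for them only; others in the source may bear on it.

Compound 3 `COc1cc(/C=N/Nc2nc(-c3ccc(F)c(F)c3)cs2)c(Br)c(Br)c1OC` is the dibromo member with a 3,4-difluorophenyl on the core. In a functional assay on HepG2 cells (Homo sapiens) for inhibition, read by MTT assay, with a stated time of 48 h (a higher number here means a weaker inhibitor, a lower number a stronger inhibitor), compound 3 gives 49700 nM, the highest of the two numbers that are known. Compound 2 `COc1cc(/C=N/Nc2nc(-c3ccc(F)c(F)c3)cs2)cc(Br)c1OC`, which carries a single bromine, gives 22400 nM in this assay, and the step of a 2.2-fold higher number from compound 2 to compound 3 (0.35 log units; beyond the scatter) is modest. Compound 1 `COc1cc(/C=N/Nc2nc(-c3ccc(C(F)(F)F)cc3)cs2)c(Br)c(Br)c1OC`, with a 4-(trifluoromethyl)phenyl on the core, reaches only the limit > 100000 nM in this assay; that value is a limit and not a number. The step of an at least 2.0-fold lower number from compound 1 to compound 3 (0.30 log units; that floor lies within the scatter) therefore stays at a floor, as the limit of > 100000 nM in this assay, at which 1 of the 3 values shown sits, shows.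

Compound 4 `COc1cc(/C=N/Nc2nc(-c3ccccc3)cs2)c(Br)c(Br)c1OC` keeps the dibromo dimethoxyphenyl part of compound 3 and changes only the aryl on the core: phenyl in place of 3,4-difluorophenyl on an aromatic carbon. Among the measured compounds shown here, the one measured step that concerns this aryl position, from compound 1 to compound 3, was small and bounded by a limit, so no firm direction follows from it. The expectation is a step in this assay no larger than the scatter, a 1.2-fold higher number from compound 3 to compound 4 (0.08 log units; within the scatter), leaning if anything towards a higher number. Compound 4 is accordingly estimated at 60000 nM, within 20000 nM to 150000 nM.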

Compound 4, half-maximal inhibitory concentration: 33600 nM
Compound 4: middle estimate off by 1.8-fold (0.25 log units), on the high side; the range from low to high includes it.
By their numbers in this assay, from the lowest: compounds 2, 4 and 3 (each within the scatter of the next, the first and the last beyond it). At a limit, above all of these: compound 1.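

At this aryl position on the core, phenyl in place of 3,4-difluorophenyl gives a 1.5-fold lower number from compound 3 to compound 4 (0.17 log units; within the scatter), so in this assay the bare phenyl and the fluorinated ring cannot be told apart, and the fluorines are not needed to keep a measurable number. Hydrogen in place of trifluoromethyl gives an at least 2.9-fold lower number from compound 1 to compound 4 (0.47 log units; beyond the scatter), which is the first step at this position to clear the scatter, whereas the floor of the earlier step on this aryl stayed inside it; within these dibromo compounds, only the 4-(trifluoromethyl)phenyl member separates from the others. Compound 1 stands at a limit and not at a number, so this step gives a floor and no true size: the limit of > 100000 nM in this assay, at which 1 of the 4 values shown sits.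

The compounds shown carry only phenyl, 3,4-difluorophenyl and 4-(trifluoromethyl)phenyl at this position, so it stays open how an amine or a carboxylic acid on that phenyl, or a longer chain in its place, would read in this assay. Whether phenyl and 3,4-difluorophenyl also stay this close with the bromine pattern of compound 2 is open as well.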